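Adding a Hydroxy Group to a Lactam-Bearing Series

A few compounds are considered here, and "the series" means these few. Any claim that something is new, unique, unknown or untested is made for them only; others in the source may bear on it.

Compound 1 `CC(C)c1noc(N2CCC(Oc3cc(N4CCc5cc(N6CCCCC6=O)ccc54)ncn3)CC2)n1` has been measured in an ADME assay on microsomes from liver (Rattus norvegicus) for metabolic stability, read by LC-MS, using NADPH, with a stated time of 30 min, tested at 1 uM (a lower number here means slower removal, a higher number faster removal of the compound), where compound 1 gives 13 mL.min-1.g-1, the lowest of the two numbers available. Among the measured compounds shown here, its only measured neighbour is compound 2 `CC(C)c1noc(N2CCC(Oc3cc(N4CCc5cc(C6CCCCC6=O)ccc54)ncn3)CC2)n1`, which in this assay gives 141 mL.min-1.g-1; the step of an 11-fold higher number from compound 1 to compound 2 (1.04 log units; beyond the scatter) exchanges one ring for another at the same point of the shared core. Compound 3 `CC(C)c1noc(N2CCC(Oc3cc(N4CCc5cc(N6CCC(O)CC6=O)ccc54)ncn3)CC2)n1` keeps the ring of compound 1 and differs from it only in that (hydroxy in place of hydrogen on a saturated ring carbon). For the measured compounds named here, the single measured step swaps the whole group rather than decorating it, so it gives no direct guide, although its size shows that this region can move the number a long way. The expectation for compound 3 is therefore a modest step of a 1.3-fold lower number from compound 1 to compound 3 (0.11 log units; within the scatter), not beyond the scatter, with an estimated value of 10 mL.min-1.g-1 in this assay and a range from 4 mL.min-1.g-1 to 25 mL.min-1.g-1.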

Compound 3, intrinsic clearance in microsomes: 13 mL.min-1.g-1
Compound 3: the middle estimate sits 1.3-fold (0.11 log units) below what was measured; the measured number falls inside the stated range.
By their numbers in this assay, from the lowest: compounds 1 and 3 (each within the scatter of the next); then compound 2.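

In this assay, a hydroxy on the saturated ring carbon three ring bonds from the ring nitrogen gives no change at the digits printed from compound 1 to compound 3 (within the scatter), so at this position the added group leaves the clearance reading of compound 1 where it stood. The lactam ring also keeps its distance from the carbocyclic ring with the hydroxy in place, with 4-hydroxy-2-oxopiperidin-1-yl replacing 2-oxocyclohexyl giving an 11-fold lower number from compound 2 to compound 3 (1.04 log units; beyond the scatter) and so matching the gap seen without the hydroxy. Nothing measured here accounts for either result.

As far as these compounds go, whether an amine, a carboxylic acid or a methoxy group on this same ring carbon would also leave the number in place remains open. So does the effect of a hydroxy on the 2-oxocyclohexyl ring of compound 2, where the number has much further to fall.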